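The source may hold more compounds than are shown below. What is called first, only, known or untested is meant among the compounds shown, and "the series" means these compounds.

Of the compounds shown here, three that share one core have been measured in an assay for inhibition of Thromboxane-A synthase (Homo sapiens), using microsomes; a lower number here means a stronger inhibitor, a higher number a weaker inhibitor. Compound 1 `O=C(O)CC/C=C\CC1COC(c2ccccc2Cl)OC1c1cccnc1` gives 48 nM, compound 2 `N#Cc1ccc(C2OCC(C/C=C\CCC(=O)O)C(c3cccnc3)O2)cc1` gives 24 nM, and compound 3 `COc1ccc(OC(C)(C)C2OCC(C/C=C\CCC(=O)O)C(c3cccnc3)O2)cc1` gives 41 nM. The three numbers lie within the usual scatter of one another, so compound 3 cannot be set above or below either of the others; it stands among them. For the measured compounds named here, the only change measured so far in one place is a 2.0-fold lower number from compound 1 to compound 2 (0.30 log units; within the scatter), a swap of the aromatic group on the saturated ring carbon that left the number within the scatter.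

Compound 4 `Cc1ccc(SC(C)(C)C2OCC(C/C=C\CCC(=O)O)C(c3cccnc3)O2)c([N+](=O)[O-])c1` differs from compound 3 elsewhere: a group of 11 heavy atoms (7 carbon, 1 nitrogen, 2 oxygen, 1 sulfur; one six-membered aromatic ring of carbon only) in place of a group of 9 heavy atoms (7 carbon, 2 oxygen; one six-membered aromatic ring of carbon only), on a saturated chain carbon bound to two saturated chain carbons and a saturated ring carbon. Going by the values given here, no measured pair bears directly on this position, and the one step that exists, between compound 1 and compound 2, was itself within the scatter. The expectation for compound 4 is therefore a step of a 1.1-fold higher number from compound 3 to compound 4 (0.04 log units; within the scatter), which is to say none beyond the scatter. Compound 4 is expected to give about 45 nM in this assay, with a likely range from 15 nM to 150 nM.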

Compound 4, half-maximal inhibitory concentration: 30 nM
Beside the measured number, compound 4's estimate is 1.5-fold (0.18 log units) above it; the measured number falls inside the stated range.
By their numbers in this assay, from the lowest: compounds 2, 4, 3 and 1 (each within the scatter of the next).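

For the compounds shown here, compound 3 and compound 4 give the first comparison at this saturated chain carbon, bound to two saturated chain carbons and a saturated ring carbon: in this assay, replacing 4-methoxyphenoxy with a group of 11 heavy atoms that includes nitrogen and sulfur gives a 1.4-fold lower number from compound 3 to compound 4 (0.14 log units; within the scatter). In this one pair, the position takes the new group, with its additional double bond outside the aromatic ring, without a step beyond the scatter. Nothing available explains this result or assigns it to any one part of the exchanged group.

The compounds shown leave open how a group with only the oxygen exchanged for sulfur would compare with compound 3. They also leave open whether an amine or a carboxylic acid on the aromatic ring at this position would stay within the scatter of compound 3.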